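A Potent Compound and Its Mirror Image

A few compounds are considered here, and "the series" means these few. Any claim that something is new, unique, unknown or untested is made for them only; others in the source may bear on it.

Compound 2 `C1=C(c2cccnc2)C[C@H]2CNC[C@@H]1C2` and compound 1 `COc1cncc(C2=CC3CC(C2)CN(C)C3)c1` have both been tested in an in vitro functional assay on SH-EP1 cells for agonist activity at Neuronal acetylcholine receptor; alpha4/beta2 (Homo sapiens), read by FLIPR and calcium flux; on this read-out higher numbers stand for an effect only at larger amounts of compound and lower numbers for an effect already at smaller amounts. Compound 2 gives 12 nM, the lowest number of the two, while compound 1 gives 5130 nM, a much higher number that lies well beyond the scatter. Compound 3 `C1=C(c2cccnc2)C[C@@H]2CNC[C@H]1C2` has not yet been measured. Compared with compound 2 it shows one change: the two compounds have the same atoms and bonds and differ only in configuration as drawn: 2 of 2 stereo elements differ (all stereocentres are inverted: mirror images); a stereocentre at a saturated ring carbon is drawn S in compound 2 and R in compound 3; a stereocentre at a saturated ring carbon is drawn R in compound 2 and S in compound 3. Going by the values given here, no step between two measured compounds with the same atoms and bonds but different configuration is available, so nothing here shows how such a change alone moves the read-out. The expectation therefore rests on the change itself and carries wide uncertainty, leaning towards a higher number for compound 3: the step of a 5.0-fold higher number from compound 2 to compound 3 (0.70 log units; beyond the scatter) is expected. Compound 3 is estimated at 60 nM, within a range from 10 nM to 600 nM.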

Compound 3, half-maximal effective concentration: 35 nM
For compound 3 the middle estimate is 1.7-fold (0.23 log units) above the measured one, within the range that was stated.
By their numbers in this assay, from the lowest: compound 2; then compound 3; then compound 1.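

In this assay, going by these compounds alone, the mirror-image pair gives the first direct reading of what configuration alone does, and inverting both stereocentres brings a 2.9-fold higher number from compound 2 to compound 3 (0.46 log units; beyond the scatter) at this receptor. The step is modest but beyond the scatter: the arrangement at these two ring carbons changes the number, yet compound 3 still gives 35 nM and so keeps acting at small amounts. This step can be traced to a single source: the fact that compounds 2 and 3 differ only in the configuration as drawn.

From the compounds shown here alone, compound 1 differs from compound 2 in more than one place, so its value cannot be set against this step, and whether configuration counts for as much on a differently substituted core stays open. Also open, going by these compounds, is how a group such as a fluorine or an amine on the shared core would act in each mirror image.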